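The source may report more compounds than this note shows. Statements on the series, on what has been measured and on what is new or still open speak of the compounds shown alone.

The assay throughout is a functional assay on MDA-MB-435 cells (Homo sapiens) for antiproliferative activity, with a stated time of 48 h; a higher number here means a weaker inhibitor of growth, a lower number a stronger inhibitor of growth. Compound 1 `Cc1cc(O)c(C2=NN(c3ccc(S(N)(=O)=O)cc3)C(c3ccccc3Cl)C2)cc1Cl` gives 1850 nM in this assay, and compound 2 `Cc1cc(O)c(C2=NN(c3ccc(S(N)(=O)=O)cc3)C(/C=C/c3ccccc3)C2)cc1Cl` gives 8870 nM. Within the data shown here, the single measured step, a 4.8-fold higher number from compound 1 to compound 2 (0.68 log units; beyond the scatter), is the only comparison available. Compound 2 therefore stands at the highest of the two numbers, with compound 1 as its nearest neighbour at a lower value. Compound 3 `COc1ccc(C2CC(c3cc(Cl)c(C)cc3O)=NN2c2ccc(S(N)(=O)=O)cc2)cc1OC` differs from compound 2 by 3,4-dimethoxyphenyl in place of 2-phenylethenyl on a saturated ring carbon. The step from compound 1 to compound 2 bears directly on this change, since it altered the same saturated ring carbon and moved the number up by a modest amount; compound 3 puts an aromatic ring back on that saturated ring carbon, as compound 1 has. A step back down is therefore expected, a 3.0-fold lower number from compound 2 to compound 3 (0.47 log units; beyond the scatter), though the two aromatic rings are not the same. Compound 3 is estimated at 3000 nM, with a likely range from 1000 nM to 9000 nM.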

Compound 3, concentration for 50% growth inhibition: 3970 nM
Estimate against measurement, compound 3: 1.3-fold (0.12 log units) below; the measured number falls inside the stated range.
By their numbers in this assay, from the lowest: compound 1; then compound 3; then compound 2.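

Replacing 2-phenylethenyl with 3,4-dimethoxyphenyl gives a 2.2-fold lower number from compound 2 to compound 3 (0.35 log units; beyond the scatter) in this assay, so both groups shown with an aromatic ring attached directly to this saturated ring carbon give lower numbers than 2-phenylethenyl. The two aromatic groups are not equivalent, however: 3,4-dimethoxyphenyl in place of 2-chlorophenyl gives a 2.1-fold higher number from compound 1 to compound 3 (0.33 log units; beyond the scatter) and leaves compound 1 with the lowest number of the three, its steps to both others lying beyond the scatter. No separate measurement bears on why the number moves with these changes.

Whether the chlorine or the two methoxy groups account for the gap between compound 1 and compound 3 stays open, as these rings differ in both. On these data alone, how an unsubstituted phenyl or a saturated cyclohexyl group on the same carbon would compare also remains open.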